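The compounds below may be only part of what the source reports. "The series", "measured", "known", "first", "only" and "open" are said of these compounds alone.

Measured compounds:
- compound 1, `CCN1CCCC1CNC(=O)c1cc(NS(=O)(=O)N(C)C)ccc1OC`: in a functional assay on the whole organism for inhibition, with Mus musculus as the target (on this read-out higher numbers stand for an effect only at larger amounts of compound and lower numbers for an effect already at smaller amounts), compound 1 gives only a limit, > 50 mg/kg
- compound 2, `CCN1CCCC1CNC(=O)c1cc(NS(=O)(=O)N(C)C)c(Cl)cc1OC`: in this assay compound 2 gives 8.3 mg/kg

Going by the values given here, compound 2 carries the only numeric value on this read-out; the other entry is a limit, compound 1 sitting at the limit of > 50 mg/kg in this assay, at which 1 of the 2 values shown sits. Among the compounds with values here, the single measured step, an at least 6.0-fold lower number from compound 1 to compound 2 (0.77 log units; beyond the scatter), is built on that limit and concerns chloro in place of hydrogen on an aromatic carbon.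

Compound 3, `CCN1CCCC1CNC(=O)c1cc(NS(N)(=O)=O)c(Cl)cc1OC`, differs from compound 2 by amino in place of dimethylamino on a sulfonyl sulfur. Within the data shown here, no measured step touches the substituent on the sulfonyl sulfur; the step of an at least 6.0-fold lower number from compound 1 to compound 2 (0.77 log units; beyond the scatter) bears only on the aromatic chloro and carries nothing over to this exchange. With no guide among the measured steps, the step expected is a 1.0-fold lower number from compound 2 to compound 3 (0.02 log units; within the scatter), i.e. none beyond the scatter, and the range is set wide. Compound 3 is therefore estimated at 8 mg/kg, between 3 mg/kg and 25 mg/kg.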

Compound 3, dose for half-maximal effect: > 50 mg/kg
Compound 3 ended at the assay's limit; the forecaster's own chance of this, stated with the estimate: 15%; middle value at least 6.2-fold (0.79 log units) from the limit.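

With the aromatic chloro held constant, the substituent on the sulfonyl sulfur also proves to matter in this assay: amino in place of dimethylamino gives an at least 6.0-fold higher number from compound 2 to compound 3 (0.77 log units; beyond the scatter). The chloro therefore is not sufficient on its own, as compound 3 keeps it and still reaches only a limit, so among the compounds shown a number appears only where chloro and dimethylamino occur together. Compound 2 remains the only compound with a numeric value, and the other two entries are limits: the limit of > 50 mg/kg in this assay, at which 2 of the 3 values shown sit.

Going by these compounds, how far compound 3 lies beyond its limit remains open, so the step has a lower bound but no measured size. Also open, on these data alone, is whether methylamino on the sulfonyl sulfur would behave like amino or dimethylamino, and whether diethylamino would retain the effect of compound 2.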